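Trimming the side chain: from compound 3 to compound 4

A few compounds are considered here, and "the series" means these few. Any claim that something is new, unique, unknown or untested is made for them only; others in the source may bear on it.

Measured in a functional assay on the whole organism (Tail, strain ICR) with Mus musculus as the target, in the tail flick test, with a stated time of 90 min, at a dose of 25 umol/kg by the oral route; a lower number here means a weaker effect, a higher number a stronger effect of the compound at the dose given:
Compound 1, `O=C(O)CC[C@H](NC(=O)CN(c1nc(Cl)nc2[nH]cnc12)C1CC1)C(=O)O`: 44.7%
Compound 2, `C[C@@H](O)[C@H](NC(=O)CN(c1nc(Cl)nc2[nH]cnc12)C1CC1)C(=O)O`: 35.9%
Compound 3, `NCCCC[C@H](NC(=O)CN(c1nc(Cl)nc2[nH]cnc12)C1CC1)C(=O)O`: 28.8%

All three share one core and differ only in the side chain on the carbon bound to the amide-type nitrogen and the carbonyl carbon. No measured number is lower than that of compound 3: the step of a number 7.1 percentage points lower from compound 2 to compound 3 (within the scatter) stays within the scatter, while a number 15.9 percentage points lower from compound 1 to compound 3 (beyond the scatter) goes beyond it. Compound 4, `C[C@H](NC(=O)CN(c1nc(Cl)nc2[nH]cnc12)C1CC1)C(=O)O`, shortens this side chain further: hydrogen in place of 3-aminopropyl on a saturated chain carbon, two bonds along the chain from an amide-type nitrogen and a carbonyl carbon. Every measured step here swaps one side chain for another at this carbon, and none was large, as a number 8.8 percentage points lower from compound 1 to compound 2 (within the scatter) shows. Compound 4 is therefore expected to give 34%, between 20% and 48%. The expected step, a number 5.2 percentage points higher from compound 3 to compound 4 (within the scatter), should stay within the scatter.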

Compound 4, a percentage reported as activity, at one dose (the size of the read-out at that dose, not a potency): 43.5%
For compound 4 the middle estimate is 9.5 percentage points below the measured one; low and high end bracket the measured number.
By their numbers in this assay, from the lowest: compounds 3, 2, 4 and 1 (each within the scatter of the next, the first and the last beyond it).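

In this assay, trimming the 4-aminobutyl side chain to methyl gives a number 14.7 percentage points higher from compound 3 to compound 4 (beyond the scatter), so a small side chain at this carbon does not lose the effect. Methyl stays level with the other two side chains, at a number 7.6 percentage points higher from compound 2 to compound 4 (within the scatter) and a number 1.2 percentage points lower from compound 1 to compound 4 (within the scatter), which means a carboxylic acid in the side chain is not needed to match compound 1. Nothing shown here gives a reason for the step from the 4-aminobutyl chain.

Going by these compounds, whether the amine or the length of that chain counts stays open. A plain butyl chain at this carbon would separate the two.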